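A few compounds are considered here, and "the series" means these few. Any claim that something is new, unique, unknown or untested is made for them only; others in the source may bear on it.

In an ADME assay on MDBK cells (Bos taurus) for cytotoxicity, read by MTT assay, with a stated time of 72 h (a higher number here means that more compound is tolerated, a lower number that less compound is tolerated), compound 3 `FC(F)(F)c1ccc(NCc2cn(-c3ccccc3)nc2-c2ccccc2)cc1` gives 34000 nM and compound 2 `FC(F)(F)c1ccc(NCc2cn(-c3ccccc3)nc2-c2ccc(C(F)(F)F)cc2)cc1` gives 26000 nM, two values within the scatter of each other. Compound 1 `Cc1ccc(NCc2cn(-c3ccccc3)nc2-c2ccc(Cl)cc2)cc1` reads > 100000 nM, which is a limit of the assay and not a number. Compound 4 `FC(F)(F)c1ccc(NCc2cn(-c3ccccc3)nc2-c2ccc(Cl)cc2)cc1` differs from compound 3 by chloro in place of hydrogen on an aromatic carbon, para to a large group. For the measured compounds named here, the one measured step that bears on this is a 1.3-fold higher number from compound 2 to compound 3 (0.12 log units; within the scatter), with hydrogen in place of trifluoromethyl on an aromatic carbon. On that small step, the change expected in this assay is none beyond the scatter, in either direction. The estimated step is a 1.1-fold lower number from compound 3 to compound 4 (0.05 log units; within the scatter). Compound 4 is expected at 30000 nM, within an estimated range of 15000 nM to 60000 nM.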

Compound 4, half-maximal cytotoxic concentration: 31000 nM
The estimate for compound 4 lay 1.0-fold (0.01 log units) below the measured number; the measured number falls inside the stated range.
By their numbers in this assay, from the lowest: compounds 2, 4 and 3 (each within the scatter of the next). At a limit, above all of these: compound 1.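

In this assay, chloro in place of hydrogen, para to a large group, gives a 1.1-fold lower number from compound 3 to compound 4 (0.04 log units; within the scatter), and chloro in place of trifluoromethyl gives a 1.2-fold higher number from compound 2 to compound 4 (0.08 log units; within the scatter), so hydrogen, chloro and trifluoromethyl at this place read alike within the scatter. For the compounds shown here, with the 4-chlorophenyl held, trifluoromethyl in place of methyl gives an at least 3.2-fold lower number from compound 1 to compound 4 (0.50 log units; beyond the scatter), the only new step beyond the scatter. Compound 1 reads > 100000 nM, which is a limit of the assay: the limit of > 100000 nM in this assay, at which 1 of the 4 values shown sits.

On these data alone, the full size of that step remains open. Also open, as far as these compounds go, is whether an amine or a carboxylic acid in place of chloro would leave the number within the scatter.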